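This account rests on a few compounds, and the source may have more. Where it says the series, first, only, none or still open, it means among the compounds named here.

Compound 1 `CCCCSC(=S)C1=C(Nc2ccc(Cl)cc2Cl)CC(C)(C)CC1=O` and compound 2 `CC1(C)CC(=O)C=C(Nc2ccc(Br)cc2)C1` were both examined in a functional assay on PBMC cells (Homo sapiens) for inhibition, read by thymidine incorporation, with a stated time of 72 h; a lower number here means a stronger inhibitor, a higher number a weaker inhibitor. Compound 1 returns only a limit there, > 50 ug/mL. Compound 2 likewise gives only a limit, > 50 ug/mL. Both results therefore sit at the limit of > 50 ug/mL in this assay, at which 2 of the 2 values shown sit, so compound 2 has no measured number of its own and stands with compound 1 at the limit of this assay rather than anywhere on its scale.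

Compound 3 `CCCCSC(=S)C1=C(Nc2ccc(Br)cc2)CC(C)(C)CC1=O` has not yet been tested. It differs from compound 2 by a group of 7 heavy atoms (5 carbon, 2 sulfur; no ring) in place of a hydrogen atom, on a double-bonded ring carbon. Among the measured compounds shown here, no measured pair in this set shares a comparable change, so the size of this step cannot be read from any step between measured compounds. Compound 1 carries a substituent of the same kind and gives > 50 ug/mL in this assay. On that basis compound 3 is expected to stay at or near the limit, with an expected step that the limit leaves unreadable from compound 2 to compound 3 amounting to nothing beyond the scatter. Compound 3 is estimated at 60 ug/mL, within a range from 20 ug/mL to 200 ug/mL.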

Compound 3, half-maximal inhibitory concentration: > 50 ug/mL
Compound 3: a limit, no number; the forecaster's own chance of this, stated with the estimate: 75%; the middle value lies beyond the limit too.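

Compound 3 also gives only a limit in this assay, > 50 ug/mL. Among the compounds shown here, no step from compound 1 or compound 2 to compound 3 can be read: the limit of > 50 ug/mL in this assay, at which 3 of the 3 values shown sit. The compounds shown leave open whether any of these structures has a measurable inhibitory concentration, and what the changed groups contribute to it.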